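A few compounds are considered here, and "the series" means these few. Any claim that something is new, unique, unknown or untested is made for them only; others in the source may bear on it.

Of the compounds shown here, three have so far been tested in an assay on CHO cells for antagonist activity at transient receptor potential cation channel subfamily V member 1 (Homo sapiens), read by scintillation counting, with a stated time of 5 min; a lower number here means a stronger inhibitor, a higher number a weaker inhibitor. Compound 1 `C[C@H](C(=O)NCc1ccc(C(F)(F)F)nc1N(Cc1ccccc1)S(=O)(=O)c1ccccc1)c1ccc(NS(C)(=O)=O)c(F)c1` gives 1.81 nM in this assay. Compound 2 `CC(C(=O)NCc1ccc(C(F)(F)F)nc1N(Cc1ccccc1)S(=O)(=O)C(C)C)c1ccc(NS(C)(=O)=O)c(F)c1` gives 6.19 nM in this assay, and compound 3 `CC(C(=O)NCc1ccc(C(F)(F)F)nc1N(Cc1ccc(F)cc1)S(=O)(=O)c1ccc(F)cc1)c1ccc(NS(C)(=O)=O)c(F)c1` gives 2.99 nM. On these numbers compound 3 and compound 1 lie within the usual scatter of each other, so nothing separates them; compound 2 lies beyond the scatter on the weaker side of compound 3. Compound 4 `COc1ccc(CN(c2nc(C(F)(F)F)ccc2CNC(=O)C(C)c2ccc(NS(C)(=O)=O)c(F)c2)S(=O)(=O)c2ccc(F)cc2)cc1` has not yet been measured. It differs from compound 3 in one place: methoxy in place of fluoro on an aromatic carbon. Seen from one bond further out, a 4-fluorobenzyl group becomes a 4-methoxybenzyl group. Among the compounds with values here, no measured pair of compounds shows this change, so its effect is not known from the numbers here. The expected step is a 1.2-fold higher number from compound 3 to compound 4 (0.07 log units; within the scatter), small and in neither direction beyond the scatter. Compound 4 is therefore estimated at 3.5 nM in this assay, with a range from 1.5 nM to 9 nM.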

Compound 4, inhibition constant: 7.9 nM
Compound 4: the middle estimate sits 2.3-fold (0.35 log units) below what was measured; low and high end bracket the measured number.
By their numbers in this assay, from the lowest: compounds 1 and 3 (each within the scatter of the next); then compounds 2 and 4 (each within the scatter of the next).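

Placed on the benzyl ring, this change is not neutral: replacing fluoro with methoxy, para to a large group, gives a 2.6-fold higher number from compound 3 to compound 4 (0.42 log units; beyond the scatter) in this assay, so what sits at this position can shift the reading by more than the usual scatter. Methoxy is the larger group and brings a hydrogen-bond acceptor that fluoro lacks, but a single pair cannot show whether either difference matters. Nothing measured here accounts for the step.

The compounds shown leave open how other groups at this position, such as chloro, methyl, hydroxy or the longer ethoxy, would compare with fluoro and methoxy. They also leave open whether the same change would give a similar step with another group on the sulfonyl, such as the isopropyl of compound 2.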